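Methoxycarbonyl in place of methoxymethyl on compound 2

This account rests on a few compounds, and the source may have more. Where it says the series, first, only, none or still open, it means among the compounds named here.

Compound 1 `NCc1ccccc1CN(Cc1nc2ccccc2[nH]1)C1CCCc2cccnc21` is an antagonist of the chemokine receptor: in a functional assay on CEM-CCRF cells for antagonist activity at C-X-C chemokine receptor type 4 (Homo sapiens), read by calcium flux (a lower number here means a stronger inhibitor, a higher number a weaker inhibitor), compound 1 gives 28 nM. Compound 2 `COCc1ccc(CN(Cc2nc3ccccc3[nH]2)C2CCCc3cccnc32)c(CN)c1` carries a methoxymethyl group on an aromatic carbon where compound 1 has hydrogen, and in this assay compound 2 gives 21 nM. The step of a 1.3-fold lower number from compound 1 to compound 2 (0.12 log units; within the scatter) is small, so the two numbers cannot be told apart, and compound 2 stands level with compound 1 on the numbers at hand.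

Compound 3 `COC(=O)c1ccc(CN(Cc2nc3ccccc3[nH]2)C2CCCc3cccnc32)c(CN)c1` differs from compound 2 only in this: methoxycarbonyl in place of methoxymethyl on an aromatic carbon. Among the measured compounds shown here, the one step that bears on this position, a 1.3-fold lower number from compound 1 to compound 2 (0.12 log units; within the scatter), shows that changing the group there left the number essentially unchanged. The step of a 1.2-fold higher number from compound 2 to compound 3 (0.08 log units; within the scatter) is therefore expected to be small, with no clear direction beyond the scatter. Compound 3 is estimated to give about 25 nM in this assay, within a range from 8 nM to 80 nM.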

Compound 3, half-maximal inhibitory concentration: 39 nM
Estimate against measurement, compound 3: 1.6-fold (0.19 log units) below, within the range that was stated.
By their numbers in this assay, from the lowest: compounds 2, 1 and 3 (each within the scatter of the next).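

Swapping methoxymethyl for methoxycarbonyl gives a 1.9-fold higher number from compound 2 to compound 3 (0.27 log units; within the scatter), and methoxycarbonyl in place of hydrogen gives a 1.4-fold higher number from compound 1 to compound 3 (0.14 log units; within the scatter); both steps lie within the scatter. So in this assay, this aromatic carbon, para to a large group, has now carried hydrogen, methoxymethyl and methoxycarbonyl, a group with a double bond outside the aromatic rings, and the three compounds cannot be told apart by their numbers. Nothing at hand explains why these numbers stay so close.

It remains open whether a group of another kind at this position, such as an amine, a carboxylic acid or a longer chain, would also stay within the scatter of these compounds. Whether any group here can move the number beyond the scatter, in either direction, is also unanswered.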